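Branching the amide side chain on a shared triazolotriazine core

The compounds below may be only part of what the source reports. "The series", "measured", "known", "first", "only" and "open" are said of these compounds alone.

Measured compounds:
Compound 1 `CN(C)c1nnc2nncn2n1`: 4840 nM
Compound 2 `CCC(=O)N1CCN(c2nnc3nncn3n2)CC1`: 10100 nM
Compound 3 `CCCC(=O)N1CCN(c2nnc3nncn3n2)CC1`: 9840 nM

In a functional assay on HL-60 cells (Homo sapiens) for inhibition, read by MTT assay, with a stated time of 72 h (on this read-out lower numbers stand for stronger inhibition and higher numbers for weaker inhibition), compound 3 stands second highest of the three numbers; compound 2 lies within the scatter of it, while compound 1 gives a lower number, beyond the scatter. Compound 4 `CC(C)(C)C(=O)N1CCN(c2nnc3nncn3n2)CC1` differs from compound 3 by tert-butyl in place of propyl on a carbonyl carbon. For the measured compounds named here, the only step that bears on this is a 1.0-fold lower number from compound 2 to compound 3 (0.01 log units; within the scatter), which lengthened the same chain without effect. A further change at the same carbonyl carbon is therefore expected to produce no step beyond the scatter, a 1.0-fold lower number from compound 3 to compound 4 (0.02 log units; within the scatter). Compound 4 is thus estimated at 9500 nM, with a range from 4500 nM to 20000 nM.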

Compound 4, half-maximal inhibitory concentration: 1380 nM
The estimate for compound 4 lay 6.9-fold (0.84 log units) above the measured number; the whole stated range lies above it.
By their numbers in this assay, from the lowest: compound 4; then compound 1; then compounds 3 and 2 (each within the scatter of the next).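

At the carbonyl carbon, where ethyl and propyl left compound 2 and compound 3 within the scatter of each other, tert-butyl gives a 7.1-fold lower number from compound 3 to compound 4 (0.85 log units; beyond the scatter) and a 7.3-fold lower number from compound 2 to compound 4 (0.86 log units; beyond the scatter) in this assay on the shared core. This position therefore responds to the change from a straight chain to tert-butyl, although lengthening the straight chain had shown no response. Nothing available here accounts for this difference.

On these data alone, it remains open whether isopropyl or cyclopropyl on the same carbonyl carbon would give a similar step, or whether it is specific to tert-butyl.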